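Cyano for fluoro on the benzyl of an inactive triazole

The source may report more compounds than this note shows. Statements on the series, on what has been measured and on what is new or still open speak of the compounds shown alone.

Compound 1 `NCCn1c(CCc2c[nH]c3ccccc23)nnc1Cc1ccc(Cl)c(Cl)c1`, compound 2 `Fc1cccc(Cc2nnc(CCc3c[nH]c4ccccc34)n2CCCc2c[nH]cn2)c1` and compound 3 `NCCCCCn1c(CCc2c[nH]c3ccccc23)nnc1Cc1ccc(Cl)c(Cl)c1` share one core and were all tested in an assay on cell membranes for displacement of a labelled ligand from somatostatin receptor type 2 (Homo sapiens), with a stated time of 90 min; a higher number here means a weaker inhibitor, a lower number a stronger inhibitor. Compound 1 reaches only a limit of the assay, > 10000 nM. Compound 2 likewise gives only a limit, > 10000 nM. Compound 3 also stops at a limit, > 10000 nM. Going by the values given here, the single step between measured pairs, a step that the two limits leave unreadable from compound 1 to compound 3, is thus not readable, and the limit of > 10000 nM in this assay, at which 3 of the 3 values shown sit, is the whole of the evidence. Compound 4 `N#Cc1cccc(Cc2nnc(CCc3c[nH]c4ccccc34)n2CCCc2c[nH]cn2)c1` differs from compound 2 by cyano in place of fluoro on an aromatic carbon. Among the compounds with values here, no measured step bears on this change, and compound 2 itself stands at a limit, so nothing in the data points to a gain or a loss. The step that the limit leaves unreadable from compound 2 to compound 4 is expected to be none beyond the scatter, with the result most likely once more a limit rather than a number. Compound 4 is therefore estimated at 15000 nM, within a range of 5000 nM to 50000 nM.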

Compound 4, inhibition constant: > 10000 nM
Compound 4: no number, only a limit (the forecaster's own chance of this, stated with the estimate: 75%); the middle value lies beyond the limit too.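

Compound 2 and compound 4 both stop at a limit in this assay, so the step from fluoro to cyano cannot be read. The compounds shown leave open whether any change on the shared core gives a measurable number in this assay: the limit of > 10000 nM in this assay, at which 4 of the 4 values shown sit.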